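Extending the amide substituent at a chemokine receptor antagonist core

A few compounds are considered here, and "the series" means these few. Any claim that something is new, unique, unknown or untested is made for them only; others in the source may bear on it.

Compound 1 `CNC(=O)c1cnc(N2CCN(C3CCN(Cc4ccc(Cl)cc4)CC3)[C@@H](C)C2)c(Cl)c1`: 32 nM
Compound 2 `C[C@H]1CN(c2ncc(C(=N)N)cc2Cl)CCN1C1CCN(Cc2ccc(Cl)cc2)CC1`: 80 nM
Compound 3 `C[C@H]1CN(c2ncc(C(N)=O)cc2Cl)CCN1C1CCN(Cc2ccc(Cl)cc2)CC1`: 39 nM

Of the compounds shown here, three sharing one core have been measured in a functional assay for antagonist activity at C-X-C chemokine receptor type 3 (Homo sapiens); a lower number here means a stronger inhibitor, a higher number a weaker inhibitor. Compound 1 `CNC(=O)c1cnc(N2CCN(C3CCN(Cc4ccc(Cl)cc4)CC3)[C@@H](C)C2)c(Cl)c1` gives 32 nM, compound 2 `C[C@H]1CN(c2ncc(C(=N)N)cc2Cl)CCN1C1CCN(Cc2ccc(Cl)cc2)CC1` gives 80 nM and compound 3 `C[C@H]1CN(c2ncc(C(N)=O)cc2Cl)CCN1C1CCN(Cc2ccc(Cl)cc2)CC1` gives 39 nM. Compound 3 thus stands second highest of the three numbers: its nearest neighbour is compound 1, with a 1.2-fold higher number from compound 1 to compound 3 (0.09 log units; within the scatter), and its furthest is compound 2, with a 2.1-fold lower number from compound 2 to compound 3 (0.31 log units; beyond the scatter).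

Compound 4 `CCNC(=O)c1cnc(N2CCN(C3CCN(Cc4ccc(Cl)cc4)CC3)[C@@H](C)C2)c(Cl)c1` differs from compound 3 by ethyl in place of hydrogen on an amide-type nitrogen. Within the data shown here, the step that bears on this is the one from compound 1 to compound 3, where a methyl on the same nitrogen was replaced by hydrogen and a 1.2-fold higher number from compound 1 to compound 3 (0.09 log units; within the scatter). A change on this nitrogen therefore moved the number little, and the step to compound 4 is expected to lie within the scatter as well. For compound 4 the estimate in this assay is 35 nM, in the range 15 nM to 80 nM. This estimate corresponds to a 1.1-fold lower number from compound 3 to compound 4 (0.05 log units; within the scatter).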

Compound 4, half-maximal inhibitory concentration: 2.3 nM
The estimate for compound 4 lay 15-fold (1.18 log units) above the measured number, outside the stated range (below it).
By their numbers in this assay, from the lowest: compound 4; then compounds 1 and 3 (each within the scatter of the next); then compound 2.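

In this assay, this amide-type nitrogen turns out to be sensitive to its substituent: ethyl in place of hydrogen gives a 17-fold lower number from compound 3 to compound 4 (1.23 log units; beyond the scatter), although the earlier change between methyl and hydrogen gave only a 1.2-fold higher number from compound 1 to compound 3 (0.09 log units; within the scatter). Extending methyl to ethyl accounts for a 14-fold lower number from compound 1 to compound 4 (1.14 log units; beyond the scatter), so the effect of this substituent does not follow from the methyl result and appears only with ethyl. The larger replacement on the aromatic carbon gives a 35-fold lower number from compound 2 to compound 4 (1.54 log units; beyond the scatter), the widest separation among these compounds.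

Nothing available explains why ethyl separates so sharply from methyl and hydrogen. From the compounds shown here alone, it also remains open whether a longer chain such as propyl or butyl, or a branched isopropyl group, on this nitrogen would keep, extend or lose the low number seen with ethyl.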